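The source may report more compounds than this note shows. Statements on the series, on what has been measured and on what is new or still open speak of the compounds shown alone.

Working notes on the series in an assay for displacement of a labelled ligand from Sigma non-opioid intracellular receptor 1 (Cavia porcellus), read by scintillation counting, with a stated time of 180 min; on this read-out lower numbers stand for stronger inhibition and higher numbers for weaker inhibition. Three compounds share one core and differ only in the group on a saturated chain carbon, three bonds along the chain from an amine nitrogen in a ring. Compound 1 `OC1CN(CCCCc2ccccc2)CCc2cc(OCc3ccccc3)ccc21` gives 293 nM. Compound 2 `OC1CN(CCCOc2ccccc2)CCc2cc(OCc3ccccc3)ccc21` gives 193 nM. Compound 3 `OC1CN(CCCSc2ccccc2)CCc2cc(OCc3ccccc3)ccc21` gives 376 nM. Compound 2 stands with the smallest of the three numbers, but a 1.5-fold lower number from compound 1 to compound 2 (0.18 log units; within the scatter) and a 1.9-fold higher number from compound 2 to compound 3 (0.29 log units; within the scatter) both lie within the scatter, as does a 1.3-fold higher number from compound 1 to compound 3 (0.11 log units; within the scatter); the three groups are not separated by these data.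

Compound 4 `O=S(=O)(CCCN1CCc2cc(OCc3ccccc3)ccc2C(O)C1)c1ccccc1` is not yet measured. Its change from compound 2: phenylsulfonyl in place of phenoxy on a saturated chain carbon, three bonds along the chain from an amine nitrogen in a ring. For the measured compounds named here, the step that bears most on it is the exchange of phenoxy for phenylsulfanyl, a 1.9-fold higher number from compound 2 to compound 3 (0.29 log units; within the scatter), which was within the scatter; no measured step reaches phenylsulfonyl itself. On that basis compound 4 is expected to stay close to compound 2, with at most a modest move toward a higher number, a 2.1-fold higher number from compound 2 to compound 4 (0.32 log units; beyond the scatter). The estimate for compound 4 in this assay is 400 nM, with a range from 120 nM to 1500 nM.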

Compound 4, inhibition constant: 349 nM
The estimate for compound 4 lay 1.1-fold (0.06 log units) above the measured number; the range from low to high includes it.
By their numbers in this assay, from the lowest: compounds 2, 1, 4 and 3 (each within the scatter of the next).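

In this assay, phenylsulfonyl on a saturated chain carbon, three bonds along the chain from an amine nitrogen in a ring, does not separate from phenoxy (a 1.8-fold higher number from compound 2 to compound 4 (0.26 log units; within the scatter)), phenylsulfanyl (a 1.1-fold lower number from compound 3 to compound 4 (0.03 log units; within the scatter)) or benzyl (a 1.2-fold higher number from compound 1 to compound 4 (0.08 log units; within the scatter)). The earlier compounds shown here showed this only for groups without double bonds outside aromatic rings, whereas phenylsulfonyl carries two such bonds and 9 heavy atoms against 7 for phenoxy, and all four groups now stand within the scatter of one another. No evidence is available that would account for this lack of separation.

Still open, as far as these compounds go, is whether the position tolerates a chain end without the phenyl ring, such as a carboxylic acid or a second amine. From the compounds shown here alone, a longer chain between the amine nitrogen and the phenylsulfonyl group also remains untested in these data.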